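A few compounds are considered here, and "the series" means these few. Any claim that something is new, unique, unknown or untested is made for them only; others in the source may bear on it.

Compound 1 `COc1ccc(/C(=C(/CCNC(=O)NC2CCCCC2)c2ccccc2)c2ccccc2)cc1`: in a functional assay on MDA-MB-231 cells (Homo sapiens) for cytotoxicity, read by MTT assay, with a stated time of 72 h (on this read-out higher numbers stand for weaker inhibition and lower numbers for stronger inhibition), compound 1 gives only a limit, > 50000 nM.
Compound 2 `COc1ccc(/C(=C(/CCNC(=O)N2CCCC2)c2ccccc2)c2ccccc2)cc1`: in this assay compound 2 likewise gives only a limit, > 50000 nM.
Compound 3 `COc1ccc(/C(=C(/CCNC(=O)C(=O)NC2CCCCC2)c2ccccc2)c2ccccc2)cc1`: in this assay compound 3 gives 12200 nM.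

Within the data shown here, compound 3 holds the only real number in this set; the other two values are limits (the limit of > 50000 nM in this assay, at which 2 of the 3 values shown sit). The steps from compound 1 to compound 3 (an at least 4.0-fold lower number from compound 1 to compound 3 (0.61 log units; beyond the scatter)) and from compound 2 to compound 3 (an at least 4.0-fold lower number from compound 2 to compound 3 (0.61 log units; beyond the scatter)) are both readable only as lower bounds, and the step from compound 1 to compound 2 (a step that the two limits leave unreadable from compound 1 to compound 2) cannot be read at all.

Compound 4 `COc1ccc(/C(=C(/CCNC(=O)C(=O)N2CCCCC2)c2ccccc2)c2ccccc2)cc1` differs from compound 3 in one place: piperidin-1-yl in place of cyclohexylamino on a carbonyl carbon. The nearest measured analogy is the step from compound 1 to compound 2, which replaces cyclohexylamino with a cyclic amine on a carbonyl carbon, but both of those compounds sit at the limit, so it gives no size. With no readable guide, compound 4 is expected to stay close to compound 3, and the step from compound 3 to compound 4 is estimated at a 1.2-fold higher number from compound 3 to compound 4 (0.09 log units; within the scatter), not beyond the scatter. Compound 4 is therefore estimated at 15000 nM, within 6000 nM to 50000 nM.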

Compound 4, half-maximal inhibitory concentration: > 50000 nM
Compound 4: no number, only a limit; the forecaster's own chance of this, stated with the estimate: 35%; at least 3.3-fold (0.52 log units) between middle value and limit.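

In this assay, piperidin-1-yl in place of cyclohexylamino, on a carbonyl carbon whose other neighbour is a carbonyl carbon, gives an at least 4.0-fold higher number from compound 3 to compound 4 (0.61 log units; beyond the scatter). The earlier compounds shown here showed a lower number only on going to cyclohexylcarbamoyl; this step shows that the second carbonyl does not carry that gain alone, as the measurable value of compound 3 is lost when the group on that carbonyl carbon changes. The steps from compound 1 and from compound 2 to compound 4 cannot be read, and compound 4 itself gives only a limit: the limit of > 50000 nM in this assay, at which 3 of the 4 values shown sit.

The change removes the amide hydrogen and also alters the ring, so the compounds shown do not separate the two. A methyl(cyclohexyl)amino group or a cyclohexylmethylamino group on the same carbonyl carbon would bear on that question.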